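This account rests on a few compounds, and the source may have more. Where it says the series, first, only, none or still open, it means among the compounds named here.

Measured so far:
Compound 1, `CCc1ccccc1NC(=O)N[C@H](C)c1ccccc1`, gives 100% in an ADME assay on the whole organism with Oryza sativa as the target, tested at 1 uM; a higher number here means a weaker effect of the compound at the concentration tested, a lower number a stronger effect.
Compound 2, `CCc1ccccc1NC(=O)N[C@@H](C)c1ccccc1`, gives 100% in this assay.
Compound 3, `CC(=O)c1cccc(NC(=O)N[C@@H](C)c2ccccc2)c1`, gives 95% in this assay.

Compound 1 stands level with compound 2, and the two together hold the highest readings of the three. The gap between compound 1 and compound 3 lies within the usual scatter of repeated measurements, so the three compounds cannot be told apart on these numbers.

Within the data shown here, only one single-change step has been measured. Going from compound 1 to compound 2 gives no change at the digits printed from compound 1 to compound 2 (within the scatter), which is consistent with the fact that compounds 1 and 2 differ only in the configuration as drawn: the two share every atom and bond and differ only in the drawn configuration at one saturated chain carbon.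

Compound 4, `C[C@@H](NC(=O)Nc1ccccc1F)c1ccccc1`, has not yet been measured. Compared with compound 1 the change is fluoro in place of ethyl on an aromatic carbon. Among the measured compounds shown here, no measured step touches this kind of exchange; the only step on record concerns configuration alone, and it showed no change. With nothing pointing in either direction, and all three readings clustered near the top of the scale, the expectation for the step of a number 3 percentage points lower from compound 1 to compound 4 (within the scatter) is no movement beyond the scatter. Compound 4 is therefore estimated at 97%, with a range from 85% to 100%.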

Compound 4, a percentage reported as activity, at one concentration (the size of the read-out at that concentration, not a potency): 95%
Compound 4: middle estimate off by 2 percentage points, on the high side; low and high end bracket the measured number.
By their numbers in this assay, from the lowest: compounds 3, 4, 1 and 2 (each within the scatter of the next).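

In this assay, putting fluoro in place of ethyl on an aromatic carbon, ortho to a large group, gives a number 5 percentage points lower from compound 1 to compound 4 (within the scatter). Among these compounds, this is the first measured step that exchanges one group for another rather than altering the drawn configuration, and it shows that going from a group of 2 heavy atoms to a group of 1 heavy atom at this place does not shift the reading by more than normal repeat variation. Nothing on record bears on this exchange, so the data offer no explanation for the result.

The compounds shown leave open whether a different group at this same place, such as an amine, a carboxylic acid or a longer chain, would bring the number down beyond the scatter, which no step so far has done. Among the compounds shown here, they also leave open whether the drawn configuration at the saturated chain carbon would stay without effect once fluoro replaces ethyl, since the only comparison of that kind rests on the ethyl pair.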